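Aryl exchanges on the amide nitrogen: notes towards compound 4

A few compounds are considered here, and "the series" means these few. Any claim that something is new, unique, unknown or untested is made for them only; others in the source may bear on it.

- Compound 1 `Cc1ccnc(C)c1NC(=O)[C@@H]1CCCN1S(=O)(=O)c1cccc2cccnc12`: > 50000 nM
- Compound 2 `O=C(Nc1ccc(Cl)cc1Cl)[C@@H]1CCCN1S(=O)(=O)c1cccc2cccnc12`: > 50000 nM
- Compound 3 `Cc1cccc(C)c1NC(=O)[C@@H]1CCCN1S(=O)(=O)c1cccc2cccnc12`: > 50000 nM

These three entries are limits, not numbers, and they come from an ADME assay on HEp-2 cells (Homo sapiens) for cytotoxicity; a higher number here means that more compound is tolerated, a lower number that less compound is tolerated. Among the measured compounds shown here, the series so far shows (the limit of > 50000 nM in this assay, at which 3 of the 3 values shown sit), so compound 3 stands there with the others. Compound 4 `Cc1ccc(Cl)c(NC(=O)[C@@H]2CCCN2S(=O)(=O)c2cccc3cccnc23)c1` carries 2-chloro-5-methylphenyl in place of 2,6-dimethylphenyl on an amide-type nitrogen. Three measured exchanges at that nitrogen bear on this: a step that the two limits leave unreadable from compound 1 to compound 2, a step that the two limits leave unreadable from compound 1 to compound 3 and a step that the two limits leave unreadable from compound 2 to compound 3. None gives a size, so no step beyond the scatter is expected in this assay. The expected change is a number no higher from compound 3 to compound 4 (the limit leaves the size open). A further limit is the likeliest report. Compound 4 is estimated at 50000 nM, with an expected range of 25000 nM to 100000 nM.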

Compound 4, half-maximal cytotoxic concentration: > 50000 nM
Compound 4: a limit, no number (the forecaster's own chance of this, stated with the estimate: 85%); the middle value sits exactly at the limit.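

Among the compounds shown here, compound 4, like compound 1, compound 2 and compound 3, gives only a limit in this assay, and no step to compound 4 can be read. The compounds shown leave open where any true half-maximal cytotoxic concentration lies, and whether these aryl exchanges alter it.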